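Swapping a benzylaminopropyl chain for a benzimidazole

This account rests on a few compounds, and the source may have more. Where it says the series, first, only, none or still open, it means among the compounds named here.

For the measured compounds named here, compound 1 `COc1c(OCCCCNCc2ccccc2)cc(O)c2c(=O)cc(-c3ccccc3)oc12` is the only member of this set with a single number in a functional assay on A549 cells (Homo sapiens) for cytotoxicity, read by MTT assay, with a stated time of 48 h; on this read-out lower numbers stand for stronger inhibition and higher numbers for weaker inhibition: compound 1 gives 4590 nM. Compound 2 `CN1CCN(CCCOc2c(O)cc(O)c3c(=O)cc(-c4ccccc4)oc23)CC1` reaches only a limit of this assay, and compound 2 is reported at > 100000 nM (the limit of > 100000 nM in this assay, at which 1 of the 3 values shown sits). For compound 3 `CCCNCCOc1c(O)cc(O)c2c(=O)cc(-c3ccccc3)oc12` no result is reported in this assay, so compound 3 stands at "not determined" (no result reported). Compound 4 `COc1c(OCc2nc3ccccc3[nH]2)cc(O)c2c(=O)cc(-c3ccccc3)oc12` has not been measured; it differs from compound 1 by 1H-benzimidazol-2-yl in place of 3-(benzylamino)propyl on a saturated chain carbon bound to an oxygen on an aromatic ring. Going by the values given here, no measured pair here differs in one place, so no step size can be drawn from the data. Compound 4 is expected to remain within reach of compound 1, with an estimated step of a 1.7-fold higher number from compound 1 to compound 4 (0.24 log units; within the scatter) from compound 1 to compound 4, giving an estimate of 8000 nM for compound 4, spanning 2000 nM to 40000 nM.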

Compound 4, half-maximal inhibitory concentration: > 100000 nM
Compound 4 was reported as a limit; the forecaster's own chance of this, stated with the estimate: 15%; middle value at least 12-fold (1.09 log units) from the limit.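

For the compounds shown here, putting 1H-benzimidazol-2-yl in place of 3-(benzylamino)propyl on a saturated chain carbon bound to an oxygen on an aromatic ring gives an at least 21-fold higher number from compound 1 to compound 4 (1.33 log units; beyond the scatter), the first step that can be read at this place. It shows that the group carried here can decide whether compound 1 keeps a measurable value. The result for compound 4 is a limit and not a number: the limit of > 100000 nM in this assay, at which 2 of the 4 values shown sit.

Which part of 3-(benzylamino)propyl matters, its amine or its carbon-only aromatic ring, stays open. So does the outcome with a dimethylamine or a carboxylic acid at the end of the chain.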